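Fluoro for methoxy on the three-carbon amide series

The compounds below may be only part of what the source reports. "The series", "measured", "known", "first", "only" and "open" are said of these compounds alone.

Measured compounds:
compound 1, `CCCC(=O)NCCCc1ccccc1OC`, 442 nM
compound 2, `CCCC(=O)NCCCc1cccc(OC)c1`, 5.5 nM
compound 3, `CCCCC(=O)NCCCCc1cccc(OC)c1`, 9670 nM

In an assay for binding affinity to melatonin receptor (Gallus gallus) (a higher number here means a weaker inhibitor, a lower number a stronger inhibitor), compound 2 gives the lowest number of the three. Compound 1 sits well above it, and compound 3 further still, both gaps beyond the scatter. Compound 4, `CCCC(=O)NCCCc1cccc(F)c1`, has not yet been measured in this assay. It differs from compound 2 by fluoro in place of methoxy on an aromatic carbon. Among the compounds with values here, no measured pair shows this exchange. The series offers no guide to its size, so the expectation rests on compound 2 alone. For compound 4 a weakening beyond the scatter is expected, a step from a 36-fold higher number from compound 2 to compound 4 (1.56 log units; beyond the scatter). Compound 4 is estimated at 200 nM, within 30 nM to 1500 nM.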

Compound 4, inhibition constant: 434 nM
Compound 4: the middle estimate sits 2.2-fold (0.34 log units) below what was measured; the measured number falls inside the stated range.
By their numbers in this assay, from the lowest: compound 2; then compounds 4 and 1 (each within the scatter of the next); then compound 3.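

In this assay, fluoro in place of methoxy on this aromatic carbon gives a 79-fold higher number from compound 2 to compound 4 (1.90 log units; beyond the scatter), a large step and the first measured size for any exchange at this position. The low number of compound 2 is therefore not kept when this smaller group enters. No measurement at hand bears on why the step is so large.

On these data alone, it remains open whether a hydroxy, ethoxy or chloro group on this carbon would lie nearer compound 2 or compound 4. Also open, as far as these compounds go, is whether the same exchange would cost as much in the core of compound 3.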